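Sulfonyl aryl exchange on an acyl sulfonamide series

The source may report more compounds than this note shows. Statements on the series, on what has been measured and on what is new or still open speak of the compounds shown alone.

Among the compounds with values here, compound 1 `CCCCC(CC)C(=O)Nc1ccc2ccn(Cc3ccc(C(=O)NS(=O)(=O)c4ccccc4C)cc3OC)c2c1` is the weaker of the two measured members. In a functional assay (trachea) for antagonist activity, with Cavia porcellus as the target (a lower number here means a less potent compound, a higher number a more potent compound, by a factor of ten per unit of this negative logarithm), compound 1 gives 8.9. Compound 2 `COc1cc(C(=O)NS(=O)(=O)c2cccs2)ccc1Cn1ccc2ccc(NC(=O)CC3CCCC3)cc21`, which carries a different amide chain and a different sulfonyl ring, reaches 9.6 in this assay, a number that stands beyond the scatter above compound 1; no single-change comparison links these two, so the gap is noted without further reading.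

Compound 3 `CCCCC(CC)C(=O)Nc1ccc2ccn(Cc3ccc(C(=O)NS(=O)(=O)c4ccc(Cl)cc4)cc3OC)c2c1` differs from compound 1 in one place: 4-chlorophenyl in place of 2-methylphenyl on a sulfonyl sulfur. Within the data shown here, no measured pair changes only this part, so nothing indicates the direction of such a change. The expected step of a number 0.20 log units higher from compound 1 to compound 3 (within the scatter) in this assay is within the scatter. Compound 3 is accordingly estimated at 9.1, with a range from 8.5 to 9.7.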

Compound 3, negative logarithm of the antagonist equilibrium constant: 7.8
The estimate for compound 3 lay 1.30 log units above the measured number; measured number below the stated range.
By their numbers in this assay, from the lowest: compound 3; then compound 1; then compound 2.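

In this assay, within the data shown here, 4-chlorophenyl in place of 2-methylphenyl on a sulfonyl sulfur gives a number 1.10 log units lower from compound 1 to compound 3 (beyond the scatter), the first single-change reading, and it shows that the number depends strongly on this sulfonyl aryl group. The two groups match in heavy atoms, in having one six-membered aromatic ring of carbon only, and in hydrogen-bond donors and acceptors, so these counts do not separate them. No measurement at hand bears on the reason for this drop.

With one pair, the loss of the methyl cannot be separated from the entry of the chlorine, and a plain phenyl on the sulfonyl sulfur would be the comparison that divides the two. On these data alone, whether a step of this size holds with the amide chain of compound 2 also remains open.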